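Fluoro to Hydroxy: Estimating Compound 3

This account rests on a few compounds, and the source may have more. Where it says the series, first, only, none or still open, it means among the compounds named here.

Compound 1 `CC1CN(c2ccccc2Sc2ccc(Cl)cc2)C(C)CN1CC(=O)O` gives 360 nM in an assay for inhibition of sodium- and chloride-dependent glycine transporter 1 (Homo sapiens); on this read-out higher numbers stand for weaker inhibition and lower numbers for stronger inhibition. Among the compounds with values here, compound 2 `CC1CN(c2ccccc2Sc2ccc(F)cc2)C(C)CN1CC(=O)O` gives 1900 nM in this assay, the highest of the two numbers measured, with the only measured step being a 5.3-fold higher number from compound 1 to compound 2 (0.72 log units; beyond the scatter). Compound 3 `CC1CN(c2ccccc2Sc2ccc(O)cc2)C(C)CN1CC(=O)O` differs from compound 2 by hydroxy in place of fluoro on an aromatic carbon. Within the data shown here, that single step bears on the same aromatic carbon and shows that a change there can move the number beyond the scatter, but no hydroxy analogue has been measured, so the direction remains open. Compound 3 is expected to give 2500 nM, within 800 nM to 8000 nM. This estimate amounts to a step of a 1.3-fold higher number from compound 2 to compound 3 (0.12 log units; within the scatter).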

Compound 3, half-maximal inhibitory concentration: 3600 nM
The estimate for compound 3 lay 1.4-fold (0.16 log units) below the measured number; low and high end bracket the measured number.
By their numbers in this assay, from the lowest: compound 1; then compounds 2 and 3 (each within the scatter of the next).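

Putting hydroxy in place of fluoro on this aromatic carbon gives a 1.9-fold higher number from compound 2 to compound 3 (0.28 log units; within the scatter) and so separates the two groups no more than repeat measurements would, even though hydroxy adds a hydrogen-bond donor that fluoro lacks. Hydroxy in place of chloro gives a 10-fold higher number from compound 1 to compound 3 (1.00 log units; beyond the scatter) and leaves compound 1 the strongest inhibitor of the three, so chloro still stands apart at this position. Nothing available explains these numbers. From the compounds shown here alone, whether bromo, methyl or an amine on this carbon would match chloro, or fall with fluoro and hydroxy, remains open.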